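The compounds below may be only part of what the source reports. "The series", "measured", "known", "first", "only" and "open" are said of these compounds alone.

Working notes on the series. Of the compounds shown here, two have numbers so far. Compound 1 `CC(C)C(c1ccc(-c2ccc3cccc(F)c3c2)[nH]c1=O)C1NC(=O)NC1=O` gives, in a functional assay on CHO cells for antagonist activity at prostaglandin E2 receptor EP3 subtype (Homo sapiens), read by cAMP accumulation, with a stated time of 30 min (a lower number here means a stronger inhibitor, a higher number a weaker inhibitor), a value of 320 nM. Compound 2 `CCC(CC)C(/C=C1\OC(=O)NC1=O)c1ccc(-c2ccc3cccc(F)c3c2)[nH]c1=O` gives in this assay a value of 23 nM, the lowest of the two numbers; the gap to compound 1 lies beyond the scatter. Compound 1 and compound 2 differ in more than one place, so only their two values can be set side by side, and no single change is attached to that gap.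

Compound 3 `O=C1NC(=O)/C(=C/C(c2ccc(-c3ccc4cccc(F)c4c3)[nH]c2=O)C2CCCCC2)O1` has not yet been measured in this assay. It is derived from compound 2 by a single change, (cyclohexyl in place of pentan-3-yl on a saturated chain carbon bound to an aromatic carbon and a double-bonded chain carbon). The group that leaves and the group that enters are both carbon-only and of similar size, and carry no donors or acceptors; compound 1, whose branched group is smaller, gives the weaker value, but since compound 1 differs from compound 2 elsewhere too, that is not a clean guide. The expectation is a step of a 1.2-fold lower number from compound 2 to compound 3 (0.06 log units; within the scatter), that is, none beyond the scatter. For compound 3 the estimated value in this assay is 20 nM, with a range from 7 nM to 60 nM.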

Compound 3, half-maximal inhibitory concentration: 8 nM
For compound 3 the middle estimate is 2.5-fold (0.40 log units) above the measured one; the range from low to high includes it.
By their numbers in this assay, from the lowest: compound 3; then compound 2; then compound 1.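

In this assay, for the compounds shown here, the saturated chain carbon bound to an aromatic carbon and a double-bonded chain carbon responds to a change between two carbon-only groups: cyclohexyl in place of pentan-3-yl gives a 2.9-fold lower number from compound 2 to compound 3 (0.46 log units; beyond the scatter) as the first single-place step. The gap between compound 1 and compound 2 could not be attached to any one change, whereas this step belongs to this position alone, and it arises although neither group carries hydrogen-bond donors or acceptors. The enhanced result is tied to an open branched group giving way to a six-membered carbon ring with one more heavy atom, but nothing measured on these compounds accounts for the lower number.

Going by these compounds alone, only two groups can be compared at this position, so it remains open whether cyclopentyl, phenyl or a piperidine ring bearing an amine would keep the number of compound 3 or shift it. Going by these compounds, it also remains open whether cyclohexyl would give a similar step in the setting of compound 1, which differs from compound 2 elsewhere as well.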